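Acyl variation on a sulfonate ester scaffold

This account rests on a few compounds, and the source may have more. Where it says the series, first, only, none or still open, it means among the compounds named here.

The three measured compounds share one core and differ only in the acyl group on the amide nitrogen. In a functional assay on M21 cells (Homo sapiens) for antiproliferative activity, read by sulforhodamine B assay, with a stated time of 48 h (on this read-out lower numbers stand for stronger inhibition and higher numbers for weaker inhibition), compound 1 `CCC(=O)Nc1ccc(S(=O)(=O)Oc2ccccc2I)cc1` gives 11000 nM, compound 2 `CCCCCC(=O)Nc1ccc(S(=O)(=O)Oc2ccccc2I)cc1` gives 11000 nM, and compound 3 `CC(C)(C)C(=O)Nc1ccc(S(=O)(=O)Oc2ccccc2I)cc1` gives 8300 nM. Compound 3 has the lowest of the three numbers, yet its neighbours sit close: a 1.3-fold lower number from compound 1 to compound 3 (0.12 log units; within the scatter) and a 1.3-fold lower number from compound 2 to compound 3 (0.12 log units; within the scatter), and no change at the digits printed from compound 1 to compound 2 (within the scatter). None of these steps reaches beyond the scatter, so no ordering among the three can be claimed.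

Compound 4 `O=C(CCCl)Nc1ccc(S(=O)(=O)Oc2ccccc2I)cc1` is the next compound. It differs from compound 3 in that (2-chloroethyl in place of tert-butyl on a carbonyl carbon). Going by the values given here, the steps that bear on this change are those that also exchanged the group on the carbonyl carbon, namely the step from compound 1 to compound 3 and the step from compound 2 to compound 3, both of which stayed within the scatter. On that basis the step from compound 3 to compound 4 is expected to be a 1.1-fold higher number from compound 3 to compound 4 (0.06 log units; within the scatter), that is, no change beyond the scatter in this assay. Compound 4 is therefore estimated at 9500 nM in this assay, with a range from 4000 nM to 22000 nM.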

Compound 4, half-maximal inhibitory concentration: 12000 nM
Compound 4: middle estimate off by 1.3-fold (0.10 log units), on the low side, and the stated range covers the measured number.
By their numbers in this assay, from the lowest: compounds 3, 1, 2 and 4 (each within the scatter of the next).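

With the 2-chloroethyl group, the acyl group on the amide nitrogen carries an atom other than carbon and hydrogen for the first time among these compounds, yet in this assay the result stays with the carbon-only groups: a 1.4-fold higher number from compound 3 to compound 4 (0.16 log units; within the scatter) and a 1.1-fold higher number from compound 1 to compound 4 (0.04 log units; within the scatter) and a 1.1-fold higher number from compound 2 to compound 4 (0.04 log units; within the scatter) are all the steps it gives. Chlorine on the saturated chain carbon, two bonds along the chain from the carbonyl carbon, therefore joins the propyl extension of compound 2 as a further exchange at this place that does not move the number beyond the scatter, and the branched tert-butyl group of compound 3 fits the same picture, so the four compounds form one flat set with no exception among them. No measurement is available that could account for this flat response.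

Going by these compounds, whether an amine, a carboxylic acid or a phenyl ring on the carbonyl carbon would shift the number beyond the scatter remains open. So does the question of whether this position matters at all in this assay or whether changes elsewhere on the shared core would have a larger effect.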